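The source may hold more compounds than are shown below. What is called first, only, known or untested is meant among the compounds shown, and "the series" means these compounds.

Compound 1 `COc1ccc(-c2nc(C(=O)/C=C\Nc3ccc4[nH]ccc4c3)c3ccccn23)cc1`: in a functional assay on A549 cells (Homo sapiens) for cytotoxicity, read by MTT assay, with a stated time of 48 h (on this read-out higher numbers stand for weaker inhibition and lower numbers for stronger inhibition), compound 1 gives 4800 nM.
Compound 2 `O=C(/C=C\Nc1ccc2cc[nH]c2c1)c1nc(-c2ccc(C(F)(F)F)cc2)n2ccccc12`: compound 2 reaches only the limit > 30000 nM in this assay.
Compound 3 `O=C(/C=C\Nc1cnc2ccccc2c1)c1nc(-c2ccccc2)n2ccccc12`: compound 3 likewise reaches only the limit > 30000 nM in this assay.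

Compound 3 therefore sits at the limit of > 30000 nM in this assay, at which 2 of the 3 values shown sit, a boundary rather than a number, so only weak inhibition is known. Compound 4 `COc1ccc(N/C=C\C(=O)c2nc(-c3ccccc3)n3ccccc23)cc1` differs from compound 3 in one place: 4-methoxyphenyl in place of quinolin-3-yl on an amine nitrogen. Among the compounds with values here, no measured pair shows a change of this kind, and compound 1, the only compound with a number, carries a different combination of groups, so it gives no direct guide. A modest move toward stronger inhibition, or none beyond the scatter, is expected, an at least 2.0-fold lower number from compound 3 to compound 4 (0.30 log units; that floor lies within the scatter). Compound 4 is expected to give 15000 nM, within 4000 nM to 40000 nM.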

Compound 4, half-maximal inhibitory concentration: > 30000 nM
Compound 4: no number, only a limit; the forecaster's own chance of this, stated with the estimate: 45%; middle value at least 2.0-fold (0.30 log units) away from the limit.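

Within the data shown here, compound 3 and compound 4 both stop at a limit rather than a number, so no step between them can be read: the limit of > 30000 nM in this assay, at which 3 of the 4 values shown sit. The compounds shown leave open whether 4-methoxyphenyl in place of quinolin-3-yl on an amine nitrogen changes inhibition at all.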